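Replacing an aryl amide with a diol chain

The source may report more compounds than this note shows. Statements on the series, on what has been measured and on what is new or still open speak of the compounds shown alone.

The shared core of these compounds carries an amide whose nitrogen substituent varies. Compound 1 `CCn1c(C(=O)NCCCN(C)C)ccc1C(CC)(CC)c1ccc(OCCC(O)(CC)CC)c(C)c1` bears a 3-(dimethylamino)propyl group there; in a functional assay on PC-3 cells (Homo sapiens) for antiproliferative activity, read by MTT assay, with a stated time of 48 h (a higher number here means a weaker inhibitor, a lower number a stronger inhibitor), compound 1 gives 2150 nM. Compound 3 `CCn1c(C(=O)Nc2cccc(C(F)(F)F)c2)ccc1C(CC)(CC)c1ccc(OCCC(O)(CC)CC)c(C)c1` carries a 3-(trifluoromethyl)phenyl group instead, and in this assay compound 3 gives 23800 nM. Compound 2 `CCn1c(C(=O)Nc2ccc(OC(F)(F)F)cc2)ccc1C(CC)(CC)c1ccc(OCCC(O)(CC)CC)c(C)c1` has a 4-(trifluoromethoxy)phenyl group. For compound 2 this assay reports only a limit, > 50000 nM, so it sits at the limit of > 50000 nM in this assay, at which 1 of the 3 values shown sits, rather than at a number. The measured steps show that swapping the alkyl amine for an aryl group weakens inhibition strongly: an at least 23-fold higher number from compound 1 to compound 2 (1.36 log units; beyond the scatter) and an 11-fold higher number from compound 1 to compound 3 (1.04 log units; beyond the scatter).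

Compound 4 `CCn1c(C(=O)NC(CO)CCO)ccc1C(CC)(CC)c1ccc(OCCC(O)(CC)CC)c(C)c1` differs from compound 2 by 3-hydroxy-1-(hydroxymethyl)propyl in place of 4-(trifluoromethoxy)phenyl on an amide-type nitrogen. This reverses the aryl-for-alkyl direction of those two steps, though the entering chain is neutral rather than basic. A move back toward the number of compound 1 is therefore expected, but not fully. Compound 4 is expected to give 9000 nM, with a range from 2500 nM to 40000 nM. That expectation corresponds to a step of an at least 5.5-fold lower number from compound 2 to compound 4 (0.74 log units; beyond the scatter).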

Compound 4, half-maximal inhibitory concentration: 8760 nM
Compound 4: the middle estimate sits 1.0-fold (0.01 log units) above what was measured, within the range that was stated.
By their numbers in this assay, from the lowest: compound 1; then compound 4; then compound 3. At a limit, above all of these: compound 2.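

Compound 4 shows that an aryl group is not required on the amide-type nitrogen: in this assay, a chain with no ring, 3-hydroxy-1-(hydroxymethyl)propyl, gives a 2.7-fold lower number from compound 3 to compound 4 (0.43 log units; beyond the scatter). Against the 4-(trifluoromethoxy)phenyl amide the change gives an at least 5.7-fold lower number from compound 2 to compound 4 (0.75 log units; beyond the scatter), which is a bound and not an exact step, since one end is only a limit: the limit of > 50000 nM in this assay, at which 1 of the 4 values shown sits. The diol chain still falls short of the 3-(dimethylamino)propyl group, with a 4.1-fold higher number from compound 1 to compound 4 (0.61 log units; beyond the scatter), so among these four compounds that group remains the one with the lowest number.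

The compounds shown do not tell whether both hydroxyl groups of compound 4 matter, or how a chain ending in a primary amine or a carboxylic acid would compare at this nitrogen. They also leave open whether this order would hold in other cell lines.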